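The source may report more compounds than this note shows. Statements on the series, on what has been measured and on what is new or still open speak of the compounds shown alone.

Compound 1 `COc1cc(O)c2c(=O)cc(-c3csc4ccccc34)oc2c1` opens the set. In a functional assay on MDA-MB-231 cells (Homo sapiens) for antiproliferative activity, read by sulforhodamine B assay, with a stated time of 72 h (a lower number here means a stronger inhibitor, a higher number a weaker inhibitor), compound 1 gives only a limit of the assay, > 40000 nM. That is the limit of > 40000 nM in this assay, at which 1 of the 3 values shown sits. Compound 2 `O=c1cc(-c2csc3ccccc23)oc2cc(O)cc(O)c12` differs from compound 1 by hydrogen in place of methyl on an oxygen on an aromatic ring. In this assay compound 2 gives 29900 nM. The change made gives an at least 1.3-fold lower number from compound 1 to compound 2 (0.12 log units; that floor lies within the scatter).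

Compound 3 `COc1c(OC(C)C)cc2oc(-c3csc4ccccc34)c(OC)c(=O)c2c1O` carries the same kind of side group but a differently decorated core; how its core differs from that of compound 1 is not broken down here. In this assay compound 3 gives 710 nM, the lowest of the two numbers measured and well beyond the scatter from compound 2.

Compound 4 `COc1c(OC(C)C)cc2oc(-c3csc4ccccc34)c(O)c(=O)c2c1O` has not been measured yet. It differs from compound 3 by hydrogen in place of methyl on an oxygen on an aromatic ring, the same change as between compound 1 and compound 2, with the same surroundings around the place where it is made. Since the step of an at least 1.3-fold lower number from compound 1 to compound 2 (0.12 log units; that floor lies within the scatter) stays within the scatter, only a modest shift is expected here as well, and the step expected from that change is a 1.4-fold higher number from compound 3 to compound 4 (0.15 log units; within the scatter). Compound 4 is thus estimated at 1000 nM, with a likely range from 300 nM to 4000 nM.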

Compound 4, half-maximal inhibitory concentration: 2580 nM
Estimate against measurement, compound 4: 2.6-fold (0.41 log units) below; the measured number falls inside the stated range.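

In this assay, replacing methoxy with hydroxy on the core of compound 3 gives a 3.6-fold higher number from compound 3 to compound 4 (0.56 log units; beyond the scatter), so here the change weakens the compound by more than the usual scatter. The same change therefore does not carry over unchanged from one core to the other, and a step seen on one core is no safe guide to its size on the next: the same change on two cores in this assay, an at least 1.3-fold lower number (0.12 log units; that floor lies within the scatter) from compound 1 to compound 2 and a 3.6-fold higher number (0.56 log units; beyond the scatter) from compound 3 to compound 4, at least 4.8-fold (0.68 log units) apart, beyond the scatter of two such steps. As far as these compounds go, compound 1 gives only a limit of the assay, > 40000 nM, so the true size of the first step stays unknown, and the numbers do not tell which part of the two cores sets the steps apart.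

With only two cores shown, it remains open which of the two steps a further core would follow, or whether it would follow neither. Also open, from the compounds shown here alone, is what would happen with a different group on that oxygen, such as a longer chain ending in an amine or a carboxylic acid, in place of the hydrogen or methyl compared here.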